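Adding an Amino Group to the Core of Compound 1

A few compounds are considered here, and "the series" means these few. Any claim that something is new, unique, unknown or untested is made for them only; others in the source may bear on it.

Measured so far in a functional assay on HL-60 cells (Homo sapiens) for cytotoxicity, read by MTT assay, with a stated time of 48 h; on this read-out lower numbers stand for stronger inhibition and higher numbers for weaker inhibition:
compound 1 `COC(=O)N/N=C/c1coc2ccccc2c1=O`: in this assay compound 1 gives 371000 nM
compound 2 `O=c1c(/C=N/Nc2cc(Cl)ccc2Cl)coc2ccccc12`: in this assay compound 2 gives 265000 nM

Within the data shown here, with only two numbers at hand, compound 1 and compound 2 lie within the usual scatter of each other, so neither can be set apart from the other in this assay. Compound 3 `COC(=O)N/N=C/c1c(N)oc2ccccc2c1=O` differs from compound 1 by amino in place of hydrogen on an aromatic carbon. Among the measured compounds shown here, no measured pair shows this change, so the expected step of a 1.2-fold lower number from compound 1 to compound 3 (0.06 log units; within the scatter) is taken as none beyond the scatter. Compound 3 is therefore expected to give about 320000 nM in this assay, within a range from 110000 nM to 950000 nM.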

Compound 3, half-maximal inhibitory concentration: 463000 nM
For compound 3 the middle estimate is 1.4-fold (0.16 log units) below the measured one, and the stated range covers the measured number.
By their numbers in this assay, from the lowest: compounds 2, 1 and 3 (each within the scatter of the next).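

Amino in place of hydrogen on the aromatic carbon next to the ring oxygen gives a 1.2-fold higher number from compound 1 to compound 3 (0.10 log units; within the scatter) and so, at this position in this assay, the amino group cannot be told apart from hydrogen. Among these compounds, this is the first step read at any position of the shared core, and it shows that this site accepts amino with no change beyond the scatter. No available evidence bears on this result. As far as these compounds go, whether a dimethylamino group or a carboxylic acid at this position would stand apart from hydrogen remains open. So does whether amino would give the same outcome with the side chain of compound 2.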